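The source may hold more compounds than are shown below. What is called first, only, known or untested is meant among the compounds shown, and "the series" means these compounds.

In a functional assay on DU-145 cells (Homo sapiens) for cytotoxicity, read by MTT assay, with a stated time of 72 h (on this read-out lower numbers stand for stronger inhibition and higher numbers for weaker inhibition), compound 1 `CC(C)NC(=S)N/N=C1\CC(c2ccc(O)cc2)Oc2cc(O)ccc21` gives 60400 nM. Compound 2 `Oc1ccc(C2C/C(=N\NC(=S)N3CCCC3)c3ccc(O)cc3O2)cc1` gives 51700 nM, which places compound 2 level with compound 1 within the scatter, so no order can be read between the two. The next compound is compound 3 `CCCCNC(=S)N/N=C1\CC(c2ccc(O)cc2)Oc2cc(O)ccc21`, and the structural change is butylamino in place of pyrrolidin-1-yl on a thiocarbonyl carbon. For the measured compounds named here, only one measured step bears on this: a 1.2-fold lower number from compound 1 to compound 2 (0.07 log units; within the scatter), for pyrrolidin-1-yl in place of isopropylamino on a thiocarbonyl carbon. That step is small and lies within the scatter. Like compound 1, compound 3 carries an alkylamino group with no ring. The expected result is a 1.0-fold lower number from compound 2 to compound 3 (0.01 log units; within the scatter), with no shift beyond the scatter anticipated in this assay. For compound 3 the estimated value is 50000 nM, with an expected range of 22000 nM to 100000 nM.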

Compound 3, half-maximal inhibitory concentration: 57700 nM
Compound 3: the middle estimate sits 1.2-fold (0.06 log units) below what was measured; measured number inside the range.
By their numbers in this assay, from the lowest: compounds 2, 3 and 1 (each within the scatter of the next).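

In this assay the change from the pyrrolidin-1-yl ring to open-chain butylamino gives a 1.1-fold higher number from compound 2 to compound 3 (0.05 log units; within the scatter) and so shows that, at this thiocarbonyl carbon, losing the ring and gaining a hydrogen-bond donor together produce no shift beyond the scatter. The earlier pair compared the ring only with isopropylamino; the new comparison on the amide-type nitrogen gives a 1.0-fold lower number from compound 1 to compound 3 (0.02 log units; within the scatter) and places butyl level with isopropyl as well. Ring, branched chain and straight chain therefore cannot be told apart among these three compounds.

On these data alone, whether a phenylamino or morpholin-4-yl group on this thiocarbonyl carbon would move the number beyond the scatter stays open. No supporting data are available to explain why these three compounds stay level.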